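The compounds below may be only part of what the source reports. "The series", "measured", "known", "first", "only" and "open" are said of these compounds alone.

Compounds measured so far: compound 1 `CC[C@@H](Nc1c(C#N)c(-c2ccc(-c3cnccc3C)cc2)nc2cnccc12)C(N)=O`, compound 2 `CC[C@@H](Nc1c(C#N)c(-c2ccc(-c3cccc(CO)c3)cc2)nc2cnccc12)C(N)=O` and compound 3 `CC(C)(CC(N)=O)c1c(C#N)c(-c2ccc(Br)cc2)nc2cnccc12`.

In a physicochemical assay for lipophilicity, read by HPLC, at pH 7.5 (a higher number here means a more lipophilic compound, a lower number a more polar compound), compound 1 gives 2, compound 2 gives 2 and compound 3 gives 2.1. Compound 2 thus stands level with compound 1, and the pair together sits at the lowest of the three numbers; compound 3 lies a little higher, but the gap between compound 2 and compound 3 is within the scatter. Going by the values given here, of the measured steps, only that from compound 1 to compound 2 is available: no change at the digits printed from compound 1 to compound 2 (within the scatter). It concerns a different pair of groups and so bears on the present question only indirectly.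

The unmeasured compound 4 `CC[C@@H](Nc1c(C#N)c(-c2ccc(-c3ccccc3Cl)cc2)nc2cnccc12)C(N)=O` differs from compound 2 as follows: 2-chlorophenyl in place of 3-(hydroxymethyl)phenyl on an aromatic carbon. The group that leaves carries one hydrogen-bond donor and one hydrogen-bond acceptor; the group that enters carries none. Among the compounds with values here, no measured step shows this change. Compound 4 is therefore expected to give a higher number in this assay than compound 2, with a step of a number 1.00 log units higher from compound 2 to compound 4 (beyond the scatter), and an estimate of 3, within 2.4 to 3.6.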

Compound 4, distribution coefficient: 2.9
The estimate for compound 4 lay 0.10 log units above the measured number; measured number inside the range.
By their numbers in this assay, from the lowest: compounds 1, 2 and 3 (each within the scatter of the next); then compound 4.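

In this assay, going by these compounds alone, the earlier step at this position stayed within the scatter (no change at the digits printed from compound 1 to compound 2 (within the scatter)), so the change of group there had not yet been seen to move the number. Placing 2-chlorophenyl on the same aromatic carbon, para to a large group, shows that the position can move it beyond the scatter, both in place of 3-(hydroxymethyl)phenyl (a number 0.90 log units higher from compound 2 to compound 4 (beyond the scatter)) and in place of 4-methylpyridin-3-yl (a number 0.90 log units higher from compound 1 to compound 4 (beyond the scatter)). Nothing measured here accounts for these rises.

The compounds shown leave open whether the rise belongs to the chlorine itself or would also appear with an unsubstituted phenyl or a fluorophenyl at this position. They also leave open where a phenyl bearing a carboxylic acid or an aminomethyl group would fall in this assay.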